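Dropping Two Fluorines from a Triazole Sulfonamide

This account rests on a few compounds, and the source may have more. Where it says the series, first, only, none or still open, it means among the compounds named here.

Measured so far:
Compound 1, `Cc1ccc(S(=O)(=O)n2cc(CN(Cc3cn(Cc4ccccc4)nn3)S(=O)(=O)c3ccccc3)c3ccccc32)cc1`, gives -18%.
Compound 2, `Cc1ccc(S(=O)(=O)N(Cc2ccccc2)Cc2cccc(F)c2F)cc1`, gives -35.7%.
Compound 3, `Cc1ccc(S(=O)(=O)N(Cc2cn(Cc3ccc(F)cc3F)nn2)Cc2cn(S(=O)(=O)c3ccc(C)cc3)c3ccccc23)cc1`, gives 12.3%.

In a functional assay on 3T3-L1 cells (Mus musculus) for inhibition, with a stated time of 20 min, tested at 20 uM (a lower number here means less inhibition, a higher number more inhibition at the concentration tested (going by the name of the read-out)), compound 3 stands highest of the three, with compound 1 the nearest and compound 2 the furthest, both beyond the scatter. Compound 4, `Cc1ccc(S(=O)(=O)N(Cc2cn(Cc3ccccc3)nn2)Cc2cn(S(=O)(=O)c3ccc(C)cc3)c3ccccc23)cc1`, is not yet measured. It differs from compound 3 in one place: phenyl in place of 2,4-difluorophenyl on a saturated chain carbon bound to an aromatic nitrogen. For the measured compounds named here, no single-change step between measured compounds exists, so the size is uncertain. Compound 1, which also carries the benzyl group, sits lower than compound 3, so a modest downward step is expected in this assay. The step from compound 3 to compound 4 is expected to be a number 17.3 percentage points lower from compound 3 to compound 4 (beyond the scatter). Compound 4 is estimated at -5%, between -30% and 20%.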

Compound 4, a percentage reported as inhibition, at one concentration (the size of the read-out at that concentration, not a potency): 3.4%
For compound 4 the middle estimate is 8.4 percentage points below the measured one, within the range that was stated.
By their numbers in this assay, from the lowest: compound 2; then compound 1; then compounds 4 and 3 (each within the scatter of the next).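

In this assay, phenyl in place of 2,4-difluorophenyl gives a number 8.9 percentage points lower from compound 3 to compound 4 (within the scatter), so the two fluorines at this place leave no difference that can be told from scatter. The other new pair, with methyl in place of hydrogen on an aromatic carbon, gives a number 21.4 percentage points higher from compound 1 to compound 4 (beyond the scatter), so a change elsewhere on the molecule does show beyond the scatter. No measurement at hand explains either step.

Going by these compounds, whether a larger change at the first place, such as a pyridine ring or an amine in place of phenyl, would move the number beyond the scatter remains open.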